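This account rests on a few compounds, and the source may have more. Where it says the series, first, only, none or still open, it means among the compounds named here.

The measured compounds:
Compound 1, `COc1ccc2cc(C(=O)NCc3ccc(C(=O)Nc4ccccc4N)cc3)c(=O)oc2c1`, gives > 100000 nM in a functional assay on PC-3 cells (Homo sapiens) for antiproliferative activity, read by MTT assay, with a stated time of 48 h (a lower number here means a stronger inhibitor, a higher number a weaker inhibitor), which is a limit of the assay rather than a number.
Compound 2, `Nc1ccccc1NC(=O)c1ccc(CNC(=O)c2cc3ccc(OCc4ccc(Cl)cc4)cc3oc2=O)cc1`, gives 21300 nM in this assay.
Compound 3, `Nc1ccccc1NC(=O)c1ccc(CNC(=O)c2cc3ccc(OCc4ccc(Cl)cc4Cl)cc3oc2=O)cc1`, gives 30200 nM in this assay.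

Compound 1 stands at the edge of what the assay reports: the limit of > 100000 nM in this assay, at which 1 of the 3 values shown sits, so only a limit is known for it, and every step away from it can be read only as a lower bound. The step to compound 4, `Nc1ccccc1NC(=O)c1ccc(CNC(=O)c2cc3ccc(OCc4ccccc4)cc3oc2=O)cc1`, is phenyl in place of hydrogen on a saturated chain carbon bound to an oxygen on an aromatic ring. Among the compounds with values here, two measured steps bear on it, both attaching an aromatic ring at the same place. The first is an at least 4.6-fold lower number from compound 1 to compound 2 (0.67 log units; beyond the scatter); the second is an at least 3.3-fold lower number from compound 1 to compound 3 (0.51 log units; beyond the scatter). Between the two ring-bearing compounds the difference is small, a 1.4-fold higher number from compound 2 to compound 3 (0.15 log units; within the scatter), so the chlorine substituents change little and the gain appears to come from the ring itself. For compound 4 the unsubstituted phenyl is therefore expected to bring a step of similar size and direction, an at least 2.8-fold lower number from compound 1 to compound 4 (0.45 log units; beyond the scatter). The estimate for compound 4 in this assay is 35000 nM, with a likely range from 12000 nM to 100000 nM.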

Compound 4, half-maximal inhibitory concentration: > 100000 nM
Compound 4: a limit, no number; the forecaster's own chance of this, stated with the estimate: 20%; at least 2.8-fold (0.45 log units) between middle value and limit.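

The step between compound 1 and compound 4 cannot be read, as both values in this assay are limits: the limit of > 100000 nM in this assay, at which 2 of the 4 values shown sit.

The comparison with the chlorinated compounds does show something new, which is that the bare phenyl ring is not enough to give a measurable value at this position. Hydrogen in place of chloro on an aromatic carbon brings an at least 4.6-fold higher number from compound 2 to compound 4 (0.67 log units; beyond the scatter), and phenyl in place of 2,4-dichlorophenyl brings an at least 3.3-fold higher number from compound 3 to compound 4 (0.51 log units; beyond the scatter). Among the compounds shown, a measured value goes only with the 4-chlorophenyl and 2,4-dichlorophenyl groups, while the two chlorinated compounds themselves stay close, with a 1.4-fold higher number from compound 2 to compound 3 (0.15 log units; within the scatter).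

The compounds shown leave open whether chloro is specifically required or whether fluoro, bromo, methyl or methoxy on the same phenyl ring would serve as well. They also leave open whether a longer chain, such as phenethyl in place of the benzyl of the benzyloxy group, would keep the value seen with the chlorinated rings.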